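Series notes: 3-fluorophenyl to 3-fluoro-2-methoxyphenyl

A few compounds are considered here, and "the series" means these few. Any claim that something is new, unique, unknown or untested is made for them only; others in the source may bear on it.

Measured so far:
compound 1 `Cc1cccc(N2C(=O)CSC2c2cccc(C(=O)NCCCCc3ccccc3)c2)c1` — 71%
compound 2 `O=C(NCCCCc1ccccc1)c1cccc(C2SCC(=O)N2c2cccc(F)c2)c1` — 63%

In a functional assay on 143B cells (Homo sapiens) for inhibition, read by CCK-8 assay, with a stated time of 72 h, tested at 1 uM (a higher number here means more inhibition at the concentration tested (going by the name of the read-out), a lower number less inhibition), compound 1 gives 71%. In this assay compound 2 gives 63%. Among the measured compounds shown here, of the two numbers, compound 2 gives the smaller one; the only measured step, a number 8 percentage points lower from compound 1 to compound 2 (within the scatter), lies within the scatter, so the two compounds cannot be told apart on these data.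

Compound 3 `COc1c(F)cccc1N1C(=O)CSC1c1cccc(C(=O)NCCCCc2ccccc2)c1` differs from compound 2 by methoxy in place of hydrogen on an aromatic carbon. For the measured compounds named here, the one measured step bears on it only loosely: it swaps one small group for another on the same ring and stays within the scatter. Going by the values given here, no measured step adds a group to that ring, so there is no direct guide. The working expectation for compound 3 is therefore a step of a number 1 percentage points lower from compound 2 to compound 3 (within the scatter), not beyond the scatter. Compound 3 is estimated at 62%, with a range from 45% to 78%.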

Compound 3, a percentage reported as inhibition, at one concentration (the size of the read-out at that concentration, not a potency): 5%
Estimate against measurement, compound 3: 57 percentage points above; the whole stated range lies above it.
By their numbers in this assay, from the lowest: compound 3; then compounds 2 and 1 (each within the scatter of the next).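

Two different groups on this ring, the methyl of compound 1 and the fluoro of compound 2, could not be told apart, so the earlier data gave no sign that the ring was sensitive to change. The aromatic carbon ortho to the fluoro group behaves differently: adding methoxy there gives, in this assay, a number 58 percentage points lower from compound 2 to compound 3 (beyond the scatter), and the 3-fluoro-2-methoxyphenyl group also compares poorly with the 3-methylphenyl group, with a number 66 percentage points lower from compound 1 to compound 3 (beyond the scatter). A small addition of 2 heavy atoms at this one carbon is thus enough to leave compound 3 at 5%, and nothing available here accounts for the loss.

On these data alone, whether the loss belongs to methoxy itself or to any group on this carbon remains open; a hydroxy, chloro or ethoxy group there would help separate the two. Also open, as far as these compounds go, is whether methoxy on the same carbon has a similar effect when the fluoro group is replaced by methyl.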